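The compounds below may be only part of what the source reports. "The series", "measured", "known", "first", "only" and "open" are said of these compounds alone.

Measured so far:
- compound 1 `N#Cc1ccc(C(=O)NC(=O)c2ccccc2O)cc1`: 55 ug/mL
- compound 2 `O=C(NC(=O)c1ccccc1O)c1ccc([N+](=O)[O-])cc1`: 53 ug/mL
- compound 3 `COc1ccc(C(=O)NC(=O)c2ccccc2O)cc1`: 39 ug/mL

In an ADME assay on L6 cells (Rattus norvegicus) for cytotoxicity, read by resazurin assay, with a stated time of 72 h (a lower number here means a stronger inhibitor, a higher number a weaker inhibitor), compound 3 lies within the scatter of both other compounds, with (a 1.4-fold lower number from compound 1 to compound 3 (0.15 log units; within the scatter)) and (a 1.4-fold lower number from compound 2 to compound 3 (0.13 log units; within the scatter)). The remaining pair is equally close (a 1.0-fold lower number from compound 1 to compound 2 (0.02 log units; within the scatter)).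

Compound 4 `CCOc1ccc(C(=O)NC(=O)c2ccccc2O)cc1` extends methoxy to ethoxy: methyl in place of hydrogen on a saturated chain carbon bound to an oxygen on an aromatic ring. This is methyl in place of hydrogen on a saturated chain carbon bound to an oxygen on an aromatic ring. Within the data shown here, no measured step makes this exact change. The three available steps exchange whole groups on an aromatic carbon, and none leaves the scatter, so no shift beyond the scatter is expected in this assay. The expected step is small (a 1.0-fold higher number from compound 3 to compound 4 (0.01 log units; within the scatter)). Compound 4 is estimated at 40 ug/mL, with an expected range from 22 ug/mL to 70 ug/mL.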

Compound 4, half-maximal inhibitory concentration: 17 ug/mL
Beside the measured number, compound 4's estimate is 2.4-fold (0.37 log units) above it, outside the stated range (below it).
By their numbers in this assay, from the lowest: compound 4; then compounds 3, 2 and 1 (each within the scatter of the next).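

In this assay, methyl in place of hydrogen on a saturated chain carbon bound to an oxygen on an aromatic ring gives a step beyond the scatter (a 2.3-fold lower number from compound 3 to compound 4 (0.36 log units; beyond the scatter)), unlike the exchanges among cyano, nitro and methoxy on an aromatic carbon, which all stayed within it. Ethoxy in place of nitro or cyano on an aromatic carbon also lies beyond the scatter (a 3.1-fold lower number from compound 2 to compound 4 (0.49 log units; beyond the scatter); a 3.2-fold lower number from compound 1 to compound 4 (0.51 log units; beyond the scatter)). Nothing available bears on what underlies this shift. On these data alone, whether a longer chain, such as propoxy, extends the step remains open. So does how an amine on the same aromatic carbon would compare with ethoxy.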